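Sulfonamide series: halogen pattern shift on the aryl ring

The source may hold more compounds than are shown below. What is called first, only, known or untested is meant among the compounds shown, and "the series" means these compounds.

Two compounds of this series carry measured numbers. Compound 1 `COc1ccc(S(=O)(=O)Nc2cc(Cl)cc(Br)c2Cl)cc1N1CCNCC1` gives 2 nM in an assay on isolated protein for binding affinity to 5-hydroxytryptamine receptor 6 (Homo sapiens); on this read-out higher numbers stand for weaker inhibition and lower numbers for stronger inhibition. Compound 2 `COc1ccc(S(=O)(=O)Nc2cc(Br)cc(Br)c2Cl)cc1N1CCNCC1` gives 2.51 nM in this assay. Among the compounds with values here, the single measured step, a 1.3-fold higher number from compound 1 to compound 2 (0.10 log units; within the scatter), is bromo in place of chloro on an aromatic carbon. On the numbers shown compound 2 stands highest of the two, with compound 1 as nearest neighbour, the gap being within the scatter.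

Compound 3 `COc1ccc(S(=O)(=O)Nc2cc(Br)cc(Cl)c2Br)cc1N1CCNCC1` has not yet been measured. It keeps the same atoms as compound 2 but joins them differently: 2,5-dibromo-3-chlorophenyl in place of 3,5-dibromo-2-chlorophenyl on a sulfonamide nitrogen. Within the data shown here, no measured step reproduces this rearrangement of the halogens around the ring; the only step on record, from compound 1 to compound 2, exchanges one halogen for another and stays within the scatter. That step bears on compound 3 only loosely. The expectation is therefore a step of size a 1.3-fold higher number from compound 2 to compound 3 (0.11 log units; within the scatter) at most, with no direction that the data can support beyond the scatter. Compound 3 is estimated to give 3.2 nM in this assay, with a range from 1.2 nM to 9 nM.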

Compound 3, inhibition constant: 3.98 nM
The estimate for compound 3 lay 1.2-fold (0.09 log units) below the measured number; low and high end bracket the measured number.
By their numbers in this assay, from the lowest: compounds 1, 2 and 3 (each within the scatter of the next).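

Within the data shown here, the exchange of 3,5-dibromo-2-chlorophenyl for 2,5-dibromo-3-chlorophenyl on a sulfonamide nitrogen is the first step that rearranges the halogens around the ring instead of swapping one halogen for another, and in this assay it reads a 1.6-fold higher number from compound 2 to compound 3 (0.20 log units; within the scatter) and so does not separate the two compounds on this read-out. The wider comparison, with 2,5-dibromo-3-chlorophenyl in place of 3-bromo-2,5-dichlorophenyl, reads a 2.0-fold higher number from compound 1 to compound 3 (0.30 log units; within the scatter) and likewise stays inside the scatter, which means that the three halogen patterns shown on this nitrogen cannot be told apart by these numbers. Nothing on record bears on how this result comes about.

Still open, on these data alone, is whether a group of another kind on this ring, such as a nitrile, a trifluoromethyl or a dimethylamino group in place of one of the halogens, would give a step beyond the scatter. Also open, as far as these compounds go, is whether the same insensitivity to the halogen pattern would hold if the methoxy group on the shared core gave way to a longer chain such as propoxy.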